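Demethylating the Aryl Ether in a Pyrazole Urea Series

This account rests on a few compounds, and the source may have more. Where it says the series, first, only, none or still open, it means among the compounds named here.

Measured so far:
compound 1 `O=C(Nc1cccc(-n2cc(-c3ccncc3)c(-c3ccc(Cl)c(O)c3)n2)c1)Nc1cccc(C(F)(F)F)c1`: 1570 nM
compound 2 `COc1cc(-c2nn(-c3cccc(NC(=O)Nc4ccc(Cl)c(C(F)(F)F)c4)c3)cc2-c2ccncc2)ccc1Cl`: 1050 nM

In a functional assay on OVCAR-8 cells (Homo sapiens) for inhibition, read by sulforhodamine B assay, with a stated time of 48 h (a lower number here means a stronger inhibitor of growth, a higher number a weaker inhibitor of growth), compound 2 gives 1050 nM, the lower of the two numbers shown, while compound 1 gives 1570 nM; the gap between them lies within the scatter, so neither can be called the stronger. Compound 3 `O=C(Nc1cccc(-n2cc(-c3ccncc3)c(-c3ccc(Cl)c(O)c3)n2)c1)Nc1ccc(Cl)c(C(F)(F)F)c1` is not yet measured. It differs from compound 2 by hydrogen in place of methyl on an oxygen on an aromatic ring, that is, methoxy to hydroxy. Compound 1 carries the same hydroxy group yet a different urea aryl, so no clean comparison exists. For compound 3 a step of no size beyond the scatter is expected, a 1.1-fold higher number from compound 2 to compound 3 (0.06 log units; within the scatter), giving an estimated 1200 nM with a range from 500 nM to 3000 nM.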

Compound 3, concentration for 50% growth inhibition: 759 nM
Compound 3: middle estimate off by 1.6-fold (0.20 log units), on the high side; measured number inside the range.
By their numbers in this assay, from the lowest: compounds 3, 2 and 1 (each within the scatter of the next, the first and the last beyond it).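

Replacing methoxy with hydroxy gives a 1.4-fold lower number from compound 2 to compound 3 (0.14 log units; within the scatter), so in this assay the two groups cannot be told apart at this position on the ring. For the compounds shown here, compound 3 also provides the first clean comparison on the urea aryl: chloro in place of hydrogen on an aromatic carbon gives a 2.1-fold lower number from compound 1 to compound 3 (0.32 log units; beyond the scatter), a modest strengthening. Nothing measured here explains either step.

Going by these compounds, it remains open whether an amine or an ethoxy group at this position would also match hydroxy. On these data alone, it is also open whether the chloro step would hold with methoxy in place of hydroxy.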